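Dimethylamino for Chloro on the Aryl Ring of Compound 2

The source may report more compounds than this note shows. Statements on the series, on what has been measured and on what is new or still open speak of the compounds shown alone.

The account concerns two aminopyrimidine compounds already tested and another that is yet to be measured in an assay on cells for inhibition of S-adenosylmethionine decarboxylase proenzyme (Homo sapiens), read by mass spectrometry, at pH 7.2; a lower number here means a stronger inhibitor, a higher number a weaker inhibitor. Compound 1 `Cc1cc(Nc2cc(Cl)cc(Cl)c2)nc(N(C)C)n1` carries a dichlorophenyl group and a dimethylamino group on the shared core. In this assay compound 1 gives only a limit, > 180000 nM. Compound 2 `Cc1cc(Nc2cc(Cl)c(Cl)c(Cl)c2)nc(N)n1` carries a trichlorophenyl group and a primary amino group on the shared core. In this assay compound 2 also gives only a limit, > 63000 nM. Compound 2 therefore stands at the limit of > 63000 nM in this assay, at which 1 of the 2 values shown sits, and compound 1 at the limit of > 180000 nM in this assay, at which 1 of the 2 values shown sits, so neither gives a number from which a ranking of the two could be drawn.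

Compound 3 `Cc1cc(Nc2cc(Cl)c(N(C)C)c(Cl)c2)nc(N)n1` differs from compound 2 in one place: dimethylamino in place of chloro on an aromatic carbon. Within the data shown here, no measured step between the two tested compounds exists to guide the size of this change. Both neighbours sit at limits, so no movement beyond the scatter is expected from compound 2 to compound 3, and compound 3 is expected to give about 100000 nM, within 30000 nM to 400000 nM, with the estimated step that the limit leaves unreadable from compound 2 to compound 3.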

Compound 3, half-maximal inhibitory concentration: > 180000 nM
Compound 3 gave a limit, no number; the forecaster's own chance of this, stated with the estimate: 80%; at least 1.8-fold (0.25 log units) between middle value and limit.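

In this assay compound 3 gives only a limit, > 180000 nM. Among these compounds, compound 2 also gives only a limit, so no step from compound 2 to compound 3 can be read. The compounds shown leave open how strongly any of the three inhibits, and whether dimethylamino in place of chloro on an aromatic carbon changes that at all.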